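A few compounds are considered here, and "the series" means these few. Any claim that something is new, unique, unknown or untested is made for them only; others in the source may bear on it.

Working notes on the series, a functional assay on MDA-MB-231 cells (Homo sapiens) for antiproliferative activity, read by MTT assay, with a stated time of 48 h; a lower number here means a stronger inhibitor, a higher number a weaker inhibitor.

Three compounds carry numbers. Compound 1 `N#Cc1cccc(Nc2ncnc3cc(NC(=O)/C=C/c4ccccc4)sc23)c1` gives 1040 nM. Compound 2 `O=C(/C=C/c1ccc(O)cc1)Nc1cc2c(Nc3ccc(Cl)c(Cl)c3)ncnc2s1` gives 1980 nM. Compound 3 `O=C(/C=C/c1ccccc1)Nc1cc2c(Nc3ccc(F)c(Cl)c3)ncnc2s1` gives 7600 nM, the highest of the three: compound 2 stands nearest, and compound 1 furthest, both gaps beyond the scatter. No two of these compounds differ in one place only, so no single step between measured compounds can be read.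

Compound 4 `O=C(/C=C/c1ccccc1)Nc1cc2c(Nc3cc(Cl)cc(Cl)c3)ncnc2s1` is not yet measured. It is derived from compound 3 by the change (3,5-dichlorophenyl in place of 3-chloro-4-fluorophenyl on a nitrogen on an aromatic ring). Among the measured compounds shown here, nothing among the measured compounds isolates this change, so the direction rests on compound 3 alone; a modest move toward a lower number is expected, a 1.9-fold lower number from compound 3 to compound 4 (0.28 log units; within the scatter), though a step within the scatter would not surprise. Compound 4 is estimated at 4000 nM, within 1500 nM to 12000 nM.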

Compound 4, half-maximal inhibitory concentration: 11500 nM
For compound 4 the middle estimate is 2.9-fold (0.46 log units) below the measured one; measured number inside the range.
By their numbers in this assay, from the lowest: compounds 1 and 2 (each within the scatter of the next); then compounds 3 and 4 (each within the scatter of the next).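

In this assay the series gains its first single-place reading, a 1.5-fold higher number from compound 3 to compound 4 (0.18 log units; within the scatter), so on this nitrogen the 3,5-dichlorophenyl and 3-chloro-4-fluorophenyl groups are not told apart. This rests on one pair of compounds sharing the same core and the same amide side. No measurement available bears on the reason for this result.

Open, going by these compounds, is whether an amine or a carboxylic acid on this phenyl ring would give a step beyond the scatter. Also open, on these data alone, is whether the same swap would read alike with a different amide side.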